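The source may report more compounds than this note shows. Statements on the series, on what has been measured and on what is new or still open speak of the compounds shown alone.

Measured compounds:
- compound 1, `Cc1cc(-c2nn(CC(O)CN3CCC(n4c(O)nc5ccc(Cl)cc54)CC3)c3c2CN(S(C)(=O)=O)CC3)ccc1Cl`, in an assay on isolated protein for inhibition of cathepsin S (Homo sapiens); a lower number here means a stronger inhibitor, a higher number a weaker inhibitor: 50 nM
- compound 2, `CS(=O)(=O)N1CCc2c(c(-c3ccc(C(F)(F)F)cc3)nn2CC(O)CN2CCC(n3c(O)nc4ccccc43)CC2)C1`, in this assay: 50 nM

Compound 2 stands level with compound 1 in this assay at the digits given; the two values lie within the usual scatter of one another, so nothing separates them. Among the compounds with values here, compound 1 and compound 2 differ in two places at once, so no single step between measured compounds is available.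

Compound 3, `CS(=O)(=O)N1CCc2c(c(-c3ccc(C(F)(F)F)cc3)nn2CC(O)CN2CCC(n3c(O)nc4ccc(Cl)cc43)CC2)C1`, is not yet measured in this assay. It differs from compound 2 in one place: chloro in place of hydrogen on an aromatic carbon. Within the data shown here, no measured pair isolates this change. Among the measured compounds shown here, the only guide is that compound 1, which carries the chloro on its fused ring system, and compound 2, which does not, give the same value; the step from compound 2 to compound 3 is therefore expected to be small, in either direction or none beyond the scatter. Compound 3 is estimated at 40 nM, with a range of 15 nM to 120 nM, which means an expected step of a 1.3-fold lower number from compound 2 to compound 3 (0.10 log units; within the scatter).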

Compound 3, half-maximal inhibitory concentration: 60 nM
For compound 3 the middle estimate is 1.5-fold (0.18 log units) below the measured one; measured number inside the range.
By their numbers in this assay, from the lowest: compounds 1, 2 and 3 (each within the scatter of the next).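

In this assay, a 1.2-fold higher number from compound 2 to compound 3 (0.08 log units; within the scatter) goes with the change from 2-hydroxy-1H-benzimidazol-1-yl to 6-chloro-2-hydroxy-1H-benzimidazol-1-yl, so chloro in place of hydrogen at this position leaves no readable effect with 4-(trifluoromethyl)phenyl on the core. Within the data shown here, with the chloro held constant, a 1.2-fold higher number from compound 1 to compound 3 (0.08 log units; within the scatter) goes with 4-(trifluoromethyl)phenyl in place of 4-chloro-3-methylphenyl, which gives the first one-place reading of that aryl change and likewise shows no readable effect. No measured property of these compounds bears on either step.

Going by these compounds, what a methoxy group, a nitrile or a carboxylic acid at this aromatic carbon would do in this assay stays open. Also open, on these data alone, is whether a simple phenyl or a pyridine in place of 4-(trifluoromethyl)phenyl would separate from these compounds at all.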